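The source may hold more compounds than are shown below. What is called first, only, known or untested is meant among the compounds shown, and "the series" means these compounds.

Measured compounds:
- compound 1 `CCn1cc(CNC(=O)[C@@H](N)CCSC[C@H]2O[C@@H](n3cnc4c(N)ncnc43)[C@H](O)[C@@H]2O)cn1` — 50000 nM
- compound 2 `Nc1ncnc2c1ncn2[C@@H]1O[C@H](CSCC[C@H](N)C(=O)NCc2cc3n(n2)CCN(Cc2ccccc2)C3)[C@@H](O)[C@H]1O` — 8000 nM

In an assay on Sf9 cells for inhibition of histone-lysine N-methyltransferase EZH2 (Homo sapiens), read by scintillation counting, in the presence of a further agent that is not named here (on this read-out lower numbers stand for stronger inhibition and higher numbers for weaker inhibition), compound 1 gives 50000 nM, the highest of the two numbers. Among the measured compounds shown here, compound 2, which carries a different group on the saturated chain carbon bound to the amide-type nitrogen, gives 8000 nM in this assay, a gap that lies beyond the scatter; no direct step between the two is computed, so only the two values themselves are noted.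

Compound 3 `Cn1nc(CNC(=O)[C@@H](N)CCSC[C@H]2O[C@@H](n3cnc4c(N)ncnc43)[C@H](O)[C@@H]2O)cc1C1CCC1` is not yet measured. It differs from compound 1 as follows: a group of 10 heavy atoms (8 carbon, 2 nitrogen; one four-membered non-aromatic ring of carbon only, one five-membered aromatic ring with 2 hetero atoms) in place of a group of 7 heavy atoms (5 carbon, 2 nitrogen; one five-membered aromatic ring with 2 hetero atoms), on a saturated chain carbon bound to an amide-type nitrogen. The added ring enlarges the group on that chain carbon while keeping the same count of hydrogen-bond donors and acceptors. The only hint in the series is that compound 2, with a larger group at the same place, gives 8000 nM against the value of compound 1; a modest step downward from compound 1 to compound 3 is therefore expected, a 3.3-fold lower number from compound 1 to compound 3 (0.52 log units; beyond the scatter), though with wide uncertainty. For compound 3 in this assay the expected value is 15000 nM, with a range from 4000 nM to 50000 nM.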

Compound 3, half-maximal inhibitory concentration: 40000 nM
Compound 3: the middle estimate sits 2.7-fold (0.43 log units) below what was measured; low and high end bracket the measured number.
By their numbers in this assay, from the lowest: compound 2; then compounds 3 and 1 (each within the scatter of the next).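

In this assay, replacing the 1-ethyl-1H-pyrazol-4-yl group with the group of 10 heavy atoms, which carries a four-membered non-aromatic ring of carbon only, on a saturated chain carbon bound to an amide-type nitrogen, gives a 1.3-fold lower number from compound 1 to compound 3 (0.10 log units; within the scatter). A larger group at this place is therefore not enough on its own to move the number beyond the scatter of compound 1, even though compound 2, also with a larger group at this place, gives 8000 nM. No supporting data bear on why the added ring leaves the two compounds within the scatter of each other.

The compounds shown leave open which part of the larger group in compound 2 goes with its number, since its group differs from the group in compound 3 in more than one feature. A phenyl ring in place of the four-membered carbon ring of compound 3, or a primary amine on that ring, would help to show whether this position responds to anything other than added heavy atoms.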